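Moving the fluorine of compound 3 to a new position

The compounds below may be only part of what the source reports. "The series", "measured", "known", "first", "only" and "open" are said of these compounds alone.

Compound 1, `CCOC(=O)c1c(-c2cccc(F)c2)csc1N`: 38%
Compound 2, `Cc1cccc(-c2csc(N)c2C(=O)OCc2ccccc2)c1`: 68%
Compound 3, `Nc1scc(-c2ccccc2F)c1C(=O)OCc1ccccc1`: 57%

All three were tested in an assay on isolated protein for inhibition of protein kinase C zeta type (Homo sapiens), with stated times of 1 h and 2.5 min, tested at 30 uM; on this read-out lower numbers stand for less inhibition and higher numbers for more inhibition at the one concentration tested (going by the name of the read-out). Compound 3 stands second highest of the three: compound 2 sits above it, separated by the step of a number 11 percentage points lower from compound 2 to compound 3 (beyond the scatter), while compound 1 lies furthest away and lower.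

Compound 4, `Nc1scc(-c2cccc(F)c2)c1C(=O)OCc1ccccc1`, differs from compound 3 by 3-fluorophenyl in place of 2-fluorophenyl on an aromatic carbon. Going by the values given here, only one measured step touches this group: a number 11 percentage points lower from compound 2 to compound 3 (beyond the scatter), where 3-methylphenyl gave the higher reading. Compound 1 also carries 3-fluorophenyl, but with an ethyl ester rather than a benzyl ester, and gives 38%. A modest rise is therefore expected, a number 5 percentage points higher from compound 3 to compound 4 (within the scatter). Compound 4 is estimated at 62%, within 45% to 78%.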

Compound 4, a percentage reported as inhibition, at one concentration (the size of the read-out at that concentration, not a potency): 53%
The estimate for compound 4 lay 9 percentage points above the measured number, and the stated range covers the measured number.
By their numbers in this assay, from the lowest: compound 1; then compounds 4 and 3 (each within the scatter of the next); then compound 2.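

In this assay, 3-fluorophenyl in place of 2-fluorophenyl gives a number 4 percentage points lower from compound 3 to compound 4 (within the scatter) and so does not separate the two fluorine placements. With the fluorine in the 3-fluorophenyl group, fluoro in place of methyl gives a number 15 percentage points lower from compound 2 to compound 4 (beyond the scatter) while, on the ester side, phenyl in place of methyl gives a number 15 percentage points higher from compound 1 to compound 4 (beyond the scatter) and shows that the benzyl ester reads higher than the ethyl ester in this pair. No supporting data explain these differences.

As far as these compounds go, whether a methoxy group or an amine on this phenyl ring would read differently stays open, as does the effect of a longer chain on the ester.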